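The source may hold more compounds than are shown below. What is called first, only, known or untested is meant among the compounds shown, and "the series" means these compounds.

Within the data shown here, only two compounds have numbers so far. In a functional assay on HCT-15 cells (Homo sapiens) for antiproliferative activity, read by CCK-8 assay, with a stated time of 72 h (on this read-out lower numbers stand for stronger inhibition and higher numbers for weaker inhibition), compound 1 (`COc1ccc(C2CC(c3ccccc3)=NN2C(=O)c2ccco2)cc1`) gives 3900 nM and compound 2 (`O=C(c1ccncc1)N1N=C(c2ccc(Cl)cc2)CC1c1ccco1`) gives 3100 nM and these two numbers lie within the usual scatter of each other. Among the measured compounds shown here, compound 1 therefore cannot be ranked against the only other measured compound. For the measured compounds named here, the two also differ in more than one place, so no measured pair isolates a single change. Compound 3 (`COc1ccc(C2CC(c3ccccc3)=NN2C(=O)c2nc3ccccc3s2)cc1`) keeps the core of compound 1 and carries 1,3-benzothiazol-2-yl in place of furan-2-yl on a carbonyl carbon. Going by the values given here, only one group changes, so its reading can be compared directly with that of compound 1. Among the compounds with values here, with no measured step to guide the estimate, the estimated change a 1.3-fold lower number from compound 1 to compound 3 (0.11 log units; within the scatter) is expected to stay within the scatter, with no firm direction. For compound 3 the estimated value is 3000 nM with an expected range from 800 nM to 10000 nM once it is measured.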

Compound 3, half-maximal inhibitory concentration: 1900 nM
Estimate against measurement, compound 3: 1.6-fold (0.20 log units) above; the measured number falls inside the stated range.
By their numbers in this assay, from the lowest: compounds 3, 2 and 1 (each within the scatter of the next, the first and the last beyond it).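

The carbonyl carbon whose other neighbour is the amide-type nitrogen in a ring now has its first measured step: in this assay, putting 1,3-benzothiazol-2-yl in place of furan-2-yl gives a 2.1-fold lower number from compound 1 to compound 3 (0.31 log units; beyond the scatter). This position therefore responds to a change of group, and the larger two-ring group is tolerated here with no loss of inhibition, although the step is modest. No separate measurement accompanies this step to show what lies behind it.

The compounds shown leave open whether the six-membered carbon ring, the sulfur or the nitrogen of the new group accounts for the step. As far as these compounds go, whether a benzofuran-2-yl or a 1,3-thiazol-2-yl group on this carbonyl carbon would read like furan-2-yl or like 1,3-benzothiazol-2-yl also remains unknown.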